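The source may hold more compounds than are shown below. What is called first, only, known or untested is meant among the compounds shown, and "the series" means these compounds.

The measured compounds:

Compound 1, `CC[C@@H]1C(=O)N(C)c2cnc(-n3ccc4cc(F)ccc43)nc2N1C1CCCC1`, gives 16000 nM
Compound 2, `CCC1C(=O)N(C)c2cnc(-n3ccc4cc(C(=O)NC(C)C)ccc43)nc2N1c1ccn(C)n1`, gives 6740 nM
Compound 3, `CC[C@@H]1C(=O)N(C)c2cnc(-n3ccc4ccccc43)nc2N1C1CCCC1`, gives 4690 nM

These three numbers come from a functional assay on Huh-7 cells (Homo sapiens) for antiproliferative activity, read by CCK-8 assay, with a stated time of 72 h; a higher number here means a weaker inhibitor of growth, a lower number a stronger inhibitor of growth. Among them compound 2 has the second highest number. Its nearest neighbour is compound 3, whose number is lower by an amount that lies within the scatter, so no order can be read between those two; compound 1 stands furthest from compound 2, with a higher number that lies beyond the scatter.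

Compound 4, `CCNC(=O)c1ccc2c(ccn2-c2ncc3c(n2)N(c2ccn(C)n2)C(CC)C(=O)N3C)c1`, has not yet been measured. It differs from compound 2 in one place: hydrogen in place of methyl on a saturated chain carbon bound to an amide-type nitrogen and a saturated chain carbon. Among the measured compounds shown here, only one measured pair differs in a single place, compound 1 and compound 3, and there the step was a 3.4-fold lower number from compound 1 to compound 3 (0.53 log units; beyond the scatter). That step concerns a fluoro on an aromatic carbon, not the isopropylcarbamoyl group, so it gives no direct guide. For the measured compounds named here, no measured pair tests the change from isopropylcarbamoyl to ethylcarbamoyl. The step from compound 2 to compound 4 is therefore expected to be a 1.0-fold lower number from compound 2 to compound 4 (0.00 log units; within the scatter), not beyond the scatter. Compound 4 is expected to give 6700 nM, with a range from 3000 nM to 15000 nM.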

Compound 4, concentration for 50% growth inhibition: 20300 nM
The estimate for compound 4 lay 3.0-fold (0.48 log units) below the measured number; measured number outside the range, above it.
By their numbers in this assay, from the lowest: compounds 3 and 2 (each within the scatter of the next); then compounds 1 and 4 (each within the scatter of the next).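

Shortening the isopropylcarbamoyl group to ethylcarbamoyl removes only a methyl, one carbon with no hydrogen-bond donor or acceptor, yet in this assay the change gives a 3.0-fold higher number from compound 2 to compound 4 (0.48 log units; beyond the scatter) as its result. This shows that growth inhibition in these cells responds to a very small edit of this side chain, so the chain's exact shape cannot be treated as a detail of no consequence. Among the compounds shown here, the earlier compounds could not show this, as their only single-place step concerned a fluoro on an aromatic carbon and said nothing about this amide side chain, and nothing available here explains why losing the methyl gives the higher number.

With only two side chains compared, a single step cannot show whether the number keeps moving in the same direction as the chain changes, or whether isopropyl is simply a better fit than ethyl. Still open, on these data alone, is how a longer chain such as n-butyl, a small ring such as cyclopropyl, or a carboxylic acid or an amine at this place would compare with isopropylcarbamoyl.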